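The compounds below may be only part of what the source reports. "The series", "measured", "known", "first", "only" and "open" are said of these compounds alone.

Measured so far in an ADME assay on BJ cells (Homo sapiens) for cytotoxicity, read by CellTiter-Glo and resazurin assay, with a stated time of 72 h; on this read-out lower numbers stand for an effect already at smaller amounts and higher numbers for an effect only at larger amounts of compound:
compound 1 `CC(C)N(Cc1cccc(OCCCCCC(=O)O)c1)C(=O)c1ccc(-c2cc3ccccc3n2S(=O)(=O)c2ccccc2)cc1` — compound 1 gives > 26000 nM, a limit of the assay.
compound 2 `COc1ccc(F)c(-c2ccc(C(=O)N(Cc3cccc(OCCCCCC(=O)O)c3)C(C)C)cc2)c1` — compound 2 gives > 26000 nM, a limit of the assay.
compound 3 `CCOC(=O)CCCCCOc1cccc(CN(C(=O)c2ccc(-c3cccc(-c4ccccc4)c3)cc2)C(C)C)c1` — compound 3 gives > 26000 nM, a limit of the assay.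

Where compound 3 stands in this assay is known only as a limit, and the same holds for the two other compounds shown, since (the limit of > 26000 nM in this assay, at which 3 of the 3 values shown sit). Within the data shown here, no difference in cytotoxicity can be read between any pair of them, and no step between measured compounds is given for this series.

The next compound, compound 4 `CCOC(=O)CCCCCOc1cccc(CN(C(=O)c2ccc(-c3cccc(OC(F)(F)F)c3)cc2)C(C)C)c1`, differs from compound 3 by one change: trifluoromethoxy in place of phenyl on an aromatic carbon. Among the measured compounds shown here, with all three measured compounds sitting at the limit, there is no measured step to lean on, and no measured property is given that would tie the entering or leaving group to a change in this assay. The expectation for this assay is therefore a step of no clear size beyond the scatter, with compound 4 most likely again returned as a limit rather than as a number.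

On that basis compound 4 is estimated at 30000 nM, with a range from 15000 nM to 60000 nM, which is expected to correspond to a step that the limit leaves unreadable from compound 3 to compound 4 of no real size.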

Compound 4, half-maximal effective concentration: > 26000 nM
Compound 4 gave a limit, no number; the forecaster's own chance of this, stated with the estimate: 85%; the middle value is on the limit's open side.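

In this assay compound 4 gives > 26000 nM as a limit and not a number. No step from compound 3 to compound 4 can be read, since both sit at the same limit: the limit of > 26000 nM in this assay, at which 4 of the 4 values shown sit.

Left open by the compounds shown is the concentration in this assay at which any of them reaches a half-maximal effect.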